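Shortening the amine substituent in a benzyl-bearing analogue

The compounds below may be only part of what the source reports. "The series", "measured", "known", "first", "only" and "open" are said of these compounds alone.

Three compounds share one core and differ only in the two groups on the amine nitrogen. Compound 1 `C=CCN(CCC)Cc1c(C(F)(F)F)nc2n(-c3c(C)cc(C)cc3C)c(Cl)cn12` gives 4.5 nM in an assay on cells for displacement of a labelled ligand from corticotropin-releasing factor receptor 1 (Homo sapiens), with a stated time of 100 min (on this read-out higher numbers stand for weaker inhibition and lower numbers for stronger inhibition), and compound 2 `C=CCN(CC=C)Cc1c(C(F)(F)F)nc2n(-c3c(C)cc(C)cc3C)c(Cl)cn12` gives 13 nM in this assay; the change is a 2.9-fold higher number from compound 1 to compound 2 (0.46 log units; beyond the scatter). Compound 3 `CCCCN(Cc1ccccc1)Cc1c(C(F)(F)F)nc2n(-c3c(C)cc(C)cc3C)c(Cl)cn12` gives 130 nM in this assay, the highest of the three numbers, lying beyond the scatter above both compound 2 and compound 1.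

Compound 4 `Cc1cc(C)c(-n2c(Cl)cn3c(CN(C)Cc4ccccc4)c(C(F)(F)F)nc23)c(C)c1` differs from compound 3 by hydrogen in place of propyl on a saturated chain carbon bound to an amine nitrogen. For the measured compounds named here, no measured pair shows this change; the only step at this position, a 2.9-fold higher number from compound 1 to compound 2 (0.46 log units; beyond the scatter), is modest and concerns a different exchange, while the gap between compound 3 and the other two shows that the substituents on this nitrogen matter. The direction of a shortening with the benzyl group kept cannot be read from these data, so the expected step of a 1.3-fold lower number from compound 3 to compound 4 (0.11 log units; within the scatter) is small and uncertain. Compound 4 is therefore estimated at 100 nM in this assay, within 30 nM to 400 nM.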

Compound 4, inhibition constant: 160 nM
For compound 4 the middle estimate is 1.6-fold (0.20 log units) below the measured one; low and high end bracket the measured number.
By their numbers in this assay, from the lowest: compound 1; then compound 2; then compounds 3 and 4 (each within the scatter of the next).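

In this assay, hydrogen in place of propyl on a saturated chain carbon bound to an amine nitrogen gives a 1.2-fold higher number from compound 3 to compound 4 (0.09 log units; within the scatter) and so stays within the scatter: with benzyl kept on the nitrogen, butyl and methyl are not told apart. Benzyl(methyl)amino in place of diallylamino gives a 12-fold higher number from compound 2 to compound 4 (1.09 log units; beyond the scatter) and in place of allyl(propyl)amino gives a 36-fold higher number from compound 1 to compound 4 (1.55 log units; beyond the scatter) as a large step. Shortening the chain therefore leaves the number of the benzyl-bearing compound 3 essentially unchanged and does not close its gap to compound 1 and compound 2. Nothing available explains these steps. Open, on these data alone, is whether a phenethyl group in place of benzyl, or a benzyl group with a methoxy group on its ring, would keep these numbers or bring them nearer those of compound 1.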